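This account rests on a few compounds, and the source may have more. Where it says the series, first, only, none or still open, it means among the compounds named here.

Compounds measured in an ADME assay on DU-145 cells (Homo sapiens) for cytotoxicity, read by MTT assay, with a stated time of 72 h; a lower number here means a stronger inhibitor, a higher number a weaker inhibitor: compound 1 `COC(=O)c1cc(C2=C(c3cc(OC)c(OC)c(OC)c3)C(=O)CC2O[SiH2]C(C)(C)C)ccc1OC` gives > 100 ug/mL, which is a limit of the assay rather than a number. Compound 2 `COc1cc(C2=C(c3ccc(OCC(=O)O)cc3)C(O)CC2=O)cc(OC)c1OC` gives > 100 ug/mL, likewise a limit. Compound 3 `COc1ccc(C2=C(c3cc(OC)c(OC)c(OC)c3)C(=O)C(O[SiH2]C(C)(C)C)C2)cc1` gives 28 ug/mL.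

Compound 1 therefore stands at the limit of > 100 ug/mL in this assay, at which 2 of the 3 values shown sit, and nothing beyond that limit is known of it. Compound 4 `COc1ccc(C2=C(c3cc(OC)c(OC)c(OC)c3)C(=O)CC2O[SiH2]C(C)(C)C)cc1` is the unmeasured analogue; the change from compound 1 is hydrogen in place of methoxycarbonyl on an aromatic carbon. Among the compounds with values here, no two measured compounds differ in a single place, so no measured step guides this one. Because compound 1 sits at the limit of > 100 ug/mL in this assay, at which 2 of the 3 values shown sit, any number found for compound 4 in this assay would point toward stronger inhibition. Compound 4 is expected to give about 50 ug/mL, within 15 ug/mL to 150 ug/mL, an expected step of an at least 2.0-fold lower number from compound 1 to compound 4 (0.30 log units; that floor lies within the scatter).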

Compound 4, half-maximal inhibitory concentration: > 100 ug/mL
Compound 4 was reported as a limit; the forecaster's own chance of this, stated with the estimate: 40%; middle value at least 2.0-fold (0.30 log units) away from the limit.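

Compound 4 gives > 100 ug/mL as a limit of the assay and not a number. Compound 1 likewise gives > 100 ug/mL as a limit, so no step can be read between compound 1 and compound 4. On these data alone, whether hydrogen in place of methoxycarbonyl changes inhibition at all stays open.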